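Iodo for Propyl on a Cinnamamide Aryl Ring

The source may hold more compounds than are shown below. What is called first, only, known or untested is meant among the compounds shown, and "the series" means these compounds.

Compound 1 `CCCc1cc(NC)c2cc(NC(=O)/C=C/c3ccc(C(F)(F)F)cc3)ccc2n1`: 1.5 nM
Compound 2 `CCCc1ccc(/C=C/C(=O)Nc2ccc3nc(CCC)cc(N)c3c2)cc1`: 4 nM
Compound 3 `Nc1cc(-c2ccccc2)nc2ccc(NC(=O)/C=C/c3ccc(C(F)(F)F)cc3)cc12`: 18.5 nM

In an assay on isolated protein for displacement of a labelled ligand from melanin-concentrating hormone receptor 1 (Homo sapiens) (a lower number here means a stronger inhibitor, a higher number a weaker inhibitor), compound 2 holds the second highest of the three numbers; compound 1 lies nearest, with a lower number beyond the scatter, and compound 3 lies furthest, with a higher number beyond the scatter. The untested compound 4 `CCCc1cc(N)c2cc(NC(=O)/C=C/c3ccc(I)cc3)ccc2n1` differs from compound 2 in one place: iodo in place of propyl on an aromatic carbon. Going by the values given here, the measured set includes no pair differing only at this position, so the size of this step is not known from the data. Compound 4 is therefore expected to stay close to compound 2 in this assay, with any step a 1.3-fold lower number from compound 2 to compound 4 (0.12 log units; within the scatter) likely within the scatter and, if anything, toward a lower number. The estimate for compound 4 is 3 nM, with a range from 1 nM to 9 nM.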

Compound 4, half-maximal inhibitory concentration: 2.3 nM
Beside the measured number, compound 4's estimate is 1.3-fold (0.12 log units) above it; the range from low to high includes it.
By their numbers in this assay, from the lowest: compounds 1, 4 and 2 (each within the scatter of the next, the first and the last beyond it); then compound 3.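

In this assay, iodo in place of propyl on this aromatic carbon gives a 1.7-fold lower number from compound 2 to compound 4 (0.24 log units; within the scatter), the first step read at this position. A single iodine atom thus takes the place of the three carbons of propyl with no change beyond the scatter, so this position tolerates both groups on the core of compound 2. Nothing at hand gives a reason for this.

On these data alone, whether an amine, a carboxylic acid or a chain longer than propyl would also stay close to compound 2 remains open. So does whether the same step would hold on the core of compound 3.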